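Methylation of the piperazine nitrogen in the benzyloxy-benzamide series

This account rests on a few compounds, and the source may have more. Where it says the series, first, only, none or still open, it means among the compounds named here.

Compound 2 `O=C(Nc1ccnnc1)c1cc(N2CCNCC2)ccc1OCc1ccccc1` sits second highest of the three compounds measured in a physicochemical assay for solubility, measured as kinetic solubility (on this read-out higher numbers stand for higher solubility and lower numbers for lower solubility), where compound 2 gives 98000 nM. Compound 1 `CN1CC2(C1)CN(c1ccc(OCc3ccccc3)c(C(=O)Nc3ccnnc3)c1)C2` gives 198000 nM in this assay, and the step of a 2.0-fold lower number from compound 1 to compound 2 (0.31 log units; beyond the scatter) separates them. Compound 3 `O=C(Nc1ccnnc1)c1cc(N2CCCC2)ccc1OCc1ccccc1` gives 35000 nM in this assay; the steps of a 2.8-fold lower number from compound 2 to compound 3 (0.45 log units; beyond the scatter) and a 5.7-fold lower number from compound 1 to compound 3 (0.75 log units; beyond the scatter) place compound 3 lowest of the three.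

Compound 4 `CN1CCN(c2ccc(OCc3ccccc3)c(C(=O)Nc3ccnnc3)c2)CC1` differs from compound 2 by methyl in place of hydrogen on an amine nitrogen in a ring. Going by the values given here, none of the measured steps bears directly on this change: each of them swaps one ring group on the aromatic carbon for another, and none holds the ring fixed while only a methyl enters on the amine nitrogen. The measured steps were modest in size, and the present change is the smallest in the set so far, a single carbon with no ring and no hydrogen-bond donor or acceptor. In this assay compound 4 is therefore expected to stay close to compound 2, with a step of a 1.1-fold lower number from compound 2 to compound 4 (0.04 log units; within the scatter) that is not expected to lie beyond the scatter. The estimate for compound 4 in this assay is 90000 nM, within a range from 40000 nM to 200000 nM.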

Compound 4, solubility: 228000 nM
Beside the measured number, compound 4's estimate is 2.5-fold (0.40 log units) below it, and the stated range ends below it.
By their numbers in this assay, from the lowest: compound 3; then compound 2; then compounds 1 and 4 (each within the scatter of the next).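

Going by these compounds alone, at the amine nitrogen in the ring of the piperazin-1-yl group, methyl in place of hydrogen gives a 2.3-fold higher number from compound 2 to compound 4 (0.37 log units; beyond the scatter) in this assay and so moves the number beyond the scatter, which the earlier steps could not show, as each of them swapped the whole ring group on the aromatic carbon and none held the ring fixed. With that single carbon, the 4-methylpiperazin-1-yl group is no longer separated from the group of 8 heavy atoms, as a 1.2-fold higher number from compound 1 to compound 4 (0.06 log units; within the scatter) lies within the scatter, and the distance from pyrrolidin-1-yl grows to a 6.5-fold higher number from compound 3 to compound 4 (0.81 log units; beyond the scatter) in the same read-out. No available data account for the size or the direction of the methyl step.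

Ethyl, acetyl or 2-hydroxyethyl on the same amine nitrogen would show whether the step belongs to methyl alone or to any group at this place. The compounds shown also leave open whether methyl in place of hydrogen on an amine nitrogen gives a similar step on a different ring group or with a different group on the shared core.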